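From a cyanobenzyl to a nitrobenzyl triazole

The source may report more compounds than this note shows. Statements on the series, on what has been measured and on what is new or still open speak of the compounds shown alone.

The series rests on a shared core carrying a bromine, an aryl group and an oxime ether that links to a benzyl-substituted triazole. Compound 1 `Cc1ccc(-c2nc3ccc(Br)cn3c2/C=N/OCc2cn(Cc3ccc([N+](=O)[O-])cc3)nn2)cc1` gives 20 mg/kg in a functional assay on the whole organism (strain NMRI) with Mus musculus as the target, with a stated time of 0.5 h; on this read-out lower numbers stand for an effect already at smaller amounts and higher numbers for an effect only at larger amounts of compound. Compound 2 `O=[N+]([O-])c1ccc(Cn2cc(CO/N=C/c3c(-c4ccc(F)cc4)nc4ccc(Br)cn34)nn2)cc1` gives 40 mg/kg, and the step of a 2.0-fold higher number from compound 1 to compound 2 (0.30 log units; within the scatter) comes with a fluoro in place of methyl on an aromatic carbon. Compound 3 `N#Cc1ccc(Cn2cc(CO/N=C/c3c(-c4ccccc4)nc4ccc(Br)cn34)nn2)cc1` gives 20 mg/kg, level with compound 1 at the digits shown, and these two together hold the lowest of the three numbers.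

Compound 4 `O=[N+]([O-])c1ccc(Cn2cc(CO/N=C/c3c(-c4ccccc4)nc4ccc(Br)cn34)nn2)cc1` differs from compound 3 by a single change: nitro in place of cyano on an aromatic carbon. Within the data shown here, none of the measured steps concerns this swap; the only step on record, from methyl to fluoro, stays within the scatter. Compounds 1 and 2, which already carry the nitrobenzyl group, sit close to compound 3 in this assay. Compound 4 is therefore expected to stay near compound 3, with a step of no change at the digits printed from compound 3 to compound 4 (within the scatter) not beyond the scatter. The estimate for compound 4 is 20 mg/kg, within 10 mg/kg to 40 mg/kg.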

Compound 4, minimum effective dose: 20 mg/kg
Beside the measured number, compound 4's estimate shows no gap at the digits printed; measured number inside the range.
By their numbers in this assay, from the lowest: compounds 1, 3, 4 and 2 (each within the scatter of the next).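

Among these compounds, the pair compound 3 and compound 4 gives the only direct reading of the 4-cyanobenzyl to 4-nitrobenzyl change in this assay, and it shows no change at the digits printed from compound 3 to compound 4 (within the scatter) on this aromatic carbon para to a large group. Compound 4 also carries plain phenyl on the shared core, which puts the aryl substituents on one scale: hydrogen in place of fluoro gives a 2.0-fold lower number from compound 2 to compound 4 (0.30 log units; within the scatter) and hydrogen in place of methyl gives no change at the digits printed from compound 1 to compound 4 (within the scatter) in the same read-out. Nothing at hand bears on what lies behind these numbers.

The compounds shown leave open how this benzyl position would respond to a group other than cyano or nitro, such as an amine or a carboxylic acid. They also leave open whether a methoxy group on the aryl ring would stay within the same narrow range.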